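Methoxy for Trifluoromethyl on the Anilino Ring

The source may hold more compounds than are shown below. What is called first, only, known or untested is meant among the compounds shown, and "the series" means these compounds.

Measured compounds:
compound 1, `COc1ccc(N/C=C\C(=O)c2cn(-c3ccccc3)nc2-c2ccccc2)cc1`, 3250 nM
compound 2, `COc1ccc(-c2nn(-c3ccccc3)cc2C(=O)/C=C\Nc2ccc(C(F)(F)F)cc2)cc1`, > 50000 nM

In a functional assay on A549 cells (Homo sapiens) for antiproliferative activity, read by MTT assay, with a stated time of 48 h (a higher number here means a weaker inhibitor, a lower number a stronger inhibitor), compound 1 gives 3250 nM. Compound 2 gives only > 50000 nM, which is a limit of the assay and not a number, so it stands at the edge of what can be measured: the limit of > 50000 nM in this assay, at which 1 of the 2 values shown sits.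

Compound 3, `COc1ccc(N/C=C\C(=O)c2cn(-c3ccccc3)nc2-c2ccc(OC)cc2)cc1`, has not been measured. It differs from compound 2 in one place: methoxy in place of trifluoromethyl on an aromatic carbon. Compound 3 therefore carries the same (4-methoxyphenyl)amino group as compound 1, which is a measured inhibitor, while compound 2 with its (4-(trifluoromethyl)phenyl)amino group is not.

For the measured compounds named here, no measured pair separates this single change, so the expectation leans on compound 1 and its value 3250 nM. Compound 3 is expected to be a stronger inhibitor than compound 2, a step of about an at least 6.2-fold lower number from compound 2 to compound 3 (0.79 log units; beyond the scatter), though its true size is hidden by the limit. The estimate for compound 3 is 8000 nM, within 2000 nM to 40000 nM.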

Compound 3, half-maximal inhibitory concentration: 6780 nM
Compound 3: middle estimate off by 1.2-fold (0.07 log units), on the high side, within the range that was stated.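

The anilino ring can now be read through a single change, with the rest of the molecule held the same: in this assay, methoxy in place of trifluoromethyl on that ring gives an at least 7.3-fold lower number from compound 2 to compound 3 (0.86 log units; beyond the scatter). The value of compound 2 is a limit of the assay and not a number, so the true size of this step stays unknown: the limit of > 50000 nM in this assay, at which 1 of the 3 values shown sits.

Methoxy in place of hydrogen on an aromatic carbon elsewhere in the molecule shifts the number much less, though still beyond the scatter: a 2.1-fold higher number from compound 1 to compound 3 (0.32 log units; beyond the scatter).

The compounds shown carry only methoxy and trifluoromethyl on the anilino ring, so they leave open how a hydroxyl group, an amine or a chlorine atom would read at that place. Plain hydrogen there remains open as well.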